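Swapping the sulfonyl aryl group: cyano out, chloro in

A few compounds are considered here, and "the series" means these few. Any claim that something is new, unique, unknown or untested is made for them only; others in the source may bear on it.

The compounds share one core carrying a methylpiperidine and a sulfonyl-linked aryl ring. In an assay on isolated protein for displacement of a labelled ligand from metabotropic glutamate receptor 5 (Homo sapiens), with a stated time of 60 min, tested at 1 uM (a lower number here means less inhibition, a higher number more inhibition at the concentration tested (going by the name of the read-out)), compound 1 `CC1CCN(c2c(S(=O)(=O)c3cccc(F)c3)cnc3ccc(Cl)cc23)CC1` gives 58%. Compound 2 `COc1ccc2ncc(S(=O)(=O)c3ccc(Cl)cc3)c(N3CCC(C)CC3)c2c1` gives 91% in this assay. Compound 3 `CC1CCN(c2c(S(=O)(=O)c3cccc(C#N)c3)cnc3ccc(Cl)cc23)CC1` gives 90% in this assay, the second highest of the three numbers; it sits within the scatter of compound 2 and well beyond the scatter from compound 1. For the measured compounds named here, the one measured single-point step, a number 32 percentage points higher from compound 1 to compound 3 (beyond the scatter), is large. Compound 4 `CC1CCN(c2c(S(=O)(=O)c3ccc(Cl)cc3)cnc3ccc(Cl)cc23)CC1` differs from compound 3 by 4-chlorophenyl in place of 3-cyanophenyl on a sulfonyl sulfur. Going by the values given here, no measured step covers exactly this change. Compound 2 also carries a 4-chlorophenyl on the sulfonyl sulfur and shows a high number, while compound 1 shows that a halogen on that ring can go with a much lower number. The estimated step is therefore a number 10 percentage points lower from compound 3 to compound 4 (within the scatter), leaning toward little loss but with a wide range. Compound 4 is expected to give about 80% in this assay, between 58% and 95%.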

Compound 4, a percentage reported as inhibition, at one concentration (the size of the read-out at that concentration, not a potency): 92%
Estimate against measurement, compound 4: 12 percentage points below, and the stated range covers the measured number.
By their numbers in this assay, from the lowest: compound 1; then compounds 3, 2 and 4 (each within the scatter of the next).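

On the sulfonyl sulfur, 4-chlorophenyl can stand in place of 3-cyanophenyl with no change beyond the scatter in this assay, a number 2 percentage points higher from compound 3 to compound 4 (within the scatter), so a nitrile is not required for a high number in this small set. A halogen on that ring does not by itself go with a low number: 4-chlorophenyl in place of 3-fluorophenyl gives a number 34 percentage points higher from compound 1 to compound 4 (beyond the scatter), a large step. On the other side of the molecule, chloro in place of methoxy on an aromatic carbon gives a number 1 percentage points higher from compound 2 to compound 4 (within the scatter), so these two groups cannot be told apart in this assay while the sulfonyl group carries 4-chlorophenyl.

Nothing measured here explains why 3-fluorophenyl stands apart from the other two rings. Still open, as far as these compounds go, are how 4-fluorophenyl would compare, which would help separate the choice of halogen from its place on the ring, and how an amine or a carboxylic acid on that ring would fare.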